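From naphthalen-2-yl to heptyl on a shared core

The source may hold more compounds than are shown below. What is called first, only, known or untested is meant among the compounds shown, and "the series" means these compounds.

In a functional assay on HeLa cells (Homo sapiens) for inhibition, read by MTT assay, with a stated time of 48 h (a higher number here means a weaker inhibitor, a lower number a stronger inhibitor), compound 1 `COc1cccc(C(c2c[nH]c3ccc(Br)cc23)c2c[nH]c3ccc(Br)cc23)c1OC` gives 64500 nM, while compound 2 `Brc1ccc2[nH]cc(C(c3ccc4ccccc4c3)c3c[nH]c4ccc(Br)cc34)c2c1` gives 4300 nM, the lower of the two numbers. Among the measured compounds shown here, the only measured step, a 15-fold lower number from compound 1 to compound 2 (1.18 log units; beyond the scatter), came with naphthalen-2-yl in place of 2,3-dimethoxyphenyl on a saturated chain carbon bound to two aromatic carbons. Compound 3 `CCCCCCCC(c1c[nH]c2ccc(Br)cc12)c1c[nH]c2ccc(Br)cc12` carries heptyl in place of naphthalen-2-yl at that same carbon: heptyl in place of naphthalen-2-yl on a saturated chain carbon bound to two aromatic carbons. For the measured compounds named here, no measured pair tests a group without a ring here, so the guidance is indirect. Going by the values given here, the earlier step, a 15-fold lower number from compound 1 to compound 2 (1.18 log units; beyond the scatter), shows only that the group at this carbon can move the number a long way. A moderate rise beyond the scatter, smaller than that step, is therefore expected. The expected change is a 2.6-fold higher number from compound 2 to compound 3 (0.41 log units; beyond the scatter). For compound 3 the estimate is 11000 nM, with an expected range of 3000 nM to 40000 nM.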

Compound 3, half-maximal inhibitory concentration: 1300 nM
Estimate against measurement, compound 3: 8.5-fold (0.93 log units) above; measured number outside the range, below it.
By their numbers in this assay, from the lowest: compound 3; then compound 2; then compound 1.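

In this assay, heptyl on a saturated chain carbon bound to two aromatic carbons gave a 3.3-fold lower number from compound 2 to compound 3 (0.52 log units; beyond the scatter), so the two six-membered aromatic rings of naphthalen-2-yl are not needed for a low number here, and a group with no ring does better. Heptyl in place of 2,3-dimethoxyphenyl gave a 50-fold lower number from compound 1 to compound 3 (1.70 log units; beyond the scatter), a larger step than the one to naphthalen-2-yl, which leaves compound 3 with the lowest number of the three. Nothing available explains why the chain outdoes both ring-bearing groups.

As far as these compounds go, whether a shorter or longer chain than heptyl would lower the number further remains open. So does whether this position would accept a chain ending in an amine or a carboxylic acid.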